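Compound 2 and a methoxy change

The source may report more compounds than this note shows. Statements on the series, on what has been measured and on what is new or still open speak of the compounds shown alone.

In an ADME assay on CCRF-CEM cells (Homo sapiens) for antiproliferative activity, with a stated time of 48 h (on this read-out higher numbers stand for weaker inhibition and lower numbers for stronger inhibition), compound 1 (`C=C(Br)C(=O)Nc1ccc(/C=C/C(=O)c2ccc(F)cc2)cc1`) gives 1100 nM and compound 2 (`C=C(Br)C(=O)Nc1ccc(C(=O)/C=C/c2ccccc2)cc1`) gives 1500 nM so these two stand within the usual scatter of each other. Compound 3 (`C=C(Br)C(=O)Nc1ccc(C(=O)/C=C/c2ccc(OC)cc2)cc1`) differs from compound 2 by a single change (methoxy in place of hydrogen on an aromatic carbon) with methoxy in place of hydrogen on an aromatic carbon, para to a large group. Among the compounds with values here, no measured pair shows this change, so the expectation here is only tentative. The expected step of a 1.7-fold lower number from compound 2 to compound 3 (0.22 log units; within the scatter) is small, leans toward stronger inhibition in this assay and stays within the scatter. For compound 3 the estimated value is 900 nM (expected range 300 nM to 2500 nM) until a measurement is available.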

Compound 3, half-maximal inhibitory concentration: 1100 nM
Compound 3: the middle estimate sits 1.2-fold (0.09 log units) below what was measured; the measured number falls inside the stated range.
By their numbers in this assay, from the lowest: compounds 1, 3 and 2 (each within the scatter of the next).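

In this assay, this position now has its first measured pair, and methoxy in place of hydrogen reads a 1.4-fold lower number from compound 2 to compound 3 (0.13 log units; within the scatter). At this site, para to a large group, phenyl to 4-methoxyphenyl therefore gives a number that cannot be told apart from that of compound 2, on this single pair. No available evidence bears on the reason for this result. From the compounds shown here alone, whether an amine, a carboxylic acid or a longer chain such as ethoxy at this position would give a step beyond the scatter stays open. So does whether methoxy gives a similar step on the core of compound 1.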